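A few compounds are considered here, and "the series" means these few. Any claim that something is new, unique, unknown or untested is made for them only; others in the source may bear on it.

Of the compounds shown here, three have so far been tested in a functional assay on M21 cells (Homo sapiens) for antiproliferative activity, with a stated time of 48 h; on this read-out higher numbers stand for weaker inhibition and lower numbers for stronger inhibition. Compound 1 `CC(C)(C)c1ccc(CNC(=O)NCCCCl)cc1` carries a 3-chloropropyl group on an amide-type nitrogen, and in this assay compound 1 gives 11000 nM. Compound 3 `CC(C)(C)c1ccc(CNC(=O)NC(=O)CCl)cc1` shares the core of compound 1 but differs by one change, ((chloromethyl)carbonyl in place of 3-chloropropyl on an amide-type nitrogen). In this assay compound 3 gives 2400 nM. That single change produced a 4.6-fold lower number from compound 1 to compound 3 (0.66 log units; beyond the scatter).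

Compound 2 `CCCCCc1cccc(NC(=O)NCCCCl)c1` is built on a different core; the difference between the two cores is not broken down here. In this assay compound 2 gives 24000 nM, which is the highest of the three numbers.

Compound 4 `CCCCCc1cccc(NC(=O)NC(=O)CCl)c1` has not yet been measured. It stands to compound 2 as compound 3 stands to compound 1: the difference is (chloromethyl)carbonyl in place of 3-chloropropyl on an amide-type nitrogen. The place of the change is described in the same words in both pairs, an amide-type nitrogen whose other neighbours are a carbonyl carbon, so this is the same change made on a second core. The expectation for compound 4 therefore rests on a single measured example. A step of about a 4.4-fold lower number from compound 2 to compound 4 (0.64 log units; beyond the scatter) is expected for compound 4, because the same change gave a 4.6-fold lower number from compound 1 to compound 3 (0.66 log units; beyond the scatter). Among the compounds with values here, since only one earlier step is available and the core is not the same, the range is kept wide. Compound 4 is estimated at 5500 nM, with a likely span from 2000 nM to 15000 nM.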

Compound 4, half-maximal inhibitory concentration: 3500 nM
Compound 4: the middle estimate sits 1.6-fold (0.20 log units) above what was measured; the measured number falls inside the stated range.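

On the second core, (chloromethyl)carbonyl in place of 3-chloropropyl on the amide-type nitrogen gives a 6.9-fold lower number from compound 2 to compound 4 (0.84 log units; beyond the scatter) in this assay. The steps on the two cores point the same way, and their sizes agree as closely as repeated measurements allow: the same change on two cores in this assay, a 4.6-fold lower number (0.66 log units; beyond the scatter) from compound 1 to compound 3 and a 6.9-fold lower number (0.84 log units; beyond the scatter) from compound 2 to compound 4, 1.5-fold (0.17 log units) apart, within the scatter of two such steps This shows that the change carried over from the core of compound 1 to the core of compound 2 in this assay, but two cores are a small sample, so it does not show that the same step would appear on a third core, nor does it reveal which part of the entering group accounts for the step.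

As far as these compounds go, what remains open is whether the chlorine matters at all: a plain acetyl group or a (bromomethyl)carbonyl group on the same nitrogen would separate the role of the chlorine from that of the carbonyl. Also open, from the compounds shown here alone, is how far the step depends on the length of the chain and on the end group, which a longer chloroalkanoyl chain or an amine in place of the chlorine, on each of the two cores, would help to settle.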